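The source may hold more compounds than are shown below. What is called first, only, known or untested is meant among the compounds shown, and "the series" means these compounds.

Measured in a functional assay on Hep 3B2 cells (Homo sapiens) for antiproliferative activity, read by MTT assay, with a stated time of 24 h; on this read-out lower numbers stand for stronger inhibition and higher numbers for weaker inhibition:
- Compound 1 `Cc1c(C(=O)Nc2c(F)cc(-c3cccc(F)c3)cc2F)nc2ccc(F)cc2c1O`: > 100000 nM, a limit of the assay.
- Compound 2 `CCOc1ccc2nc(C(=O)Nc3c(F)cc(-c4cccc(F)c4)cc3F)c(C)c(O)c2c1`: > 100000 nM, a limit of the assay.
- Compound 3 `Cc1c(C(=O)Nc2c(F)cc(-c3cccc(F)c3)cc2F)nc2ccc(OC(F)(F)F)cc2c1O`: 85500 nM.

Within the data shown here, compound 3 carries the only number in the set, 85500 nM. The other two compounds sit at the limit of > 100000 nM in this assay, at which 2 of the 3 values shown sit.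

Compound 4 `Cc1c(C(=O)Nc2c(F)cc(-c3cccc(F)c3)cc2F)nc2ccc(C(F)(F)F)cc2c1O` has trifluoromethyl in place of trifluoromethoxy on an aromatic carbon. The change lies on a six-membered aromatic ring of carbon only, part of a fused or bridged system of two rings, and the rest of the structure is shared with compound 3.

Among the measured compounds shown here, all the measured steps change the group at this same place. Trifluoromethoxy in place of fluoro gives an at least 1.1-fold lower number from compound 1 to compound 3 (0.06 log units; that floor lies within the scatter). Trifluoromethyl in place of ethyl on an oxygen gives an at least 1.1-fold lower number from compound 2 to compound 3 (0.06 log units; that floor lies within the scatter). Ethoxy in place of fluoro gives a step that the two limits leave unreadable from compound 1 to compound 2. None of these steps is shown to exceed the scatter, and each is bounded by a limit, so their true sizes remain open.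

On that basis, no step beyond the scatter is expected. The expected step, a 1.1-fold higher number from compound 3 to compound 4 (0.02 log units; within the scatter), is an estimate that stays within the scatter. A report of only a limit would fit the series equally well. For compound 4 the estimated value is 90000 nM, with an expected range of 40000 nM to 160000 nM.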

Compound 4, half-maximal inhibitory concentration: 29900 nM
For compound 4 the middle estimate is 3.0-fold (0.48 log units) above the measured one; the whole stated range lies above it.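

In this assay, among these compounds, the group on this aromatic carbon now has a readable effect for the first time: trifluoromethyl in place of trifluoromethoxy gives a 2.9-fold lower number from compound 3 to compound 4 (0.46 log units; beyond the scatter), a change that removes only the oxygen from the group. Trifluoromethyl in place of ethoxy gives an at least 3.3-fold lower number from compound 2 to compound 4 (0.52 log units; beyond the scatter), and trifluoromethyl in place of fluoro gives an at least 3.3-fold lower number from compound 1 to compound 4 (0.52 log units; beyond the scatter), so compound 4 is the most potent of the four shown, with all its steps to the others beyond the scatter. The earlier steps at this place showed no such separation, and none of them can be read as a true size, because the values of compound 1 and compound 2 are limits and not numbers: the limit of > 100000 nM in this assay, at which 2 of the 4 values shown sit.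

From the compounds shown here alone, the true size of the steps from compound 1 and compound 2 to compound 4 stays open, as those steps are only floors. Going by these compounds, with four groups at this carbon, it also stays open whether trifluoromethyl is a special case or part of a wider trend, and how a nitrile, an amine, a carboxylic acid or a longer chain such as propoxy would read here.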